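The source may report more compounds than this note shows. Statements on the series, on what has been measured and on what is new or still open speak of the compounds shown alone.

In a functional assay on cells (T-cell line, Homo sapiens) for inhibition (a higher number here means a weaker inhibitor, a lower number a stronger inhibitor), compound 1 `CCCCCN1CCC(COC(c2ccccc2)c2ccccc2)CC1` gives 10800 nM, while compound 2 `CCCCCCCN1CCC(COC(c2ccccc2)c2ccccc2)CC1` gives 500 nM. Compound 2 therefore has the lower of the two numbers and is the stronger inhibitor of the pair. Compound 3 `CCCCCCCCCN1CCC(COC(c2ccccc2)c2ccccc2)CC1` keeps the shared core and extends the chain on the amine nitrogen in a ring: ethyl in place of hydrogen on a saturated chain carbon, seven bonds along the chain from an amine nitrogen in a ring.

Within the data shown here, only one measured step bears on this change, the same exchange made five bonds along the chain. That large step is a 22-fold lower number from compound 1 to compound 2 (1.33 log units; beyond the scatter). A single step cannot show how far such a trend continues, so in this assay the number is expected to fall again, but by a smaller step, and it might barely change. The estimated change is a 3.3-fold lower number from compound 2 to compound 3 (0.52 log units; beyond the scatter). For compound 3 the expected value is 150 nM, with an estimated range from 30 nM to 700 nM.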

Compound 3, half-maximal inhibitory concentration: 700 nM
Compound 3: middle estimate off by 4.7-fold (0.67 log units), on the low side; low and high end bracket the measured number.
By their numbers in this assay, from the lowest: compounds 2 and 3 (each within the scatter of the next); then compound 1.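

Placing ethyl seven bonds along the chain from the amine nitrogen in a ring does not repeat the large earlier step: in this assay the change is a 1.4-fold higher number from compound 2 to compound 3 (0.15 log units; within the scatter), so compounds 2 and 3 cannot be told apart here. The sharp improvement seen with ethyl five bonds along the chain therefore does not carry on to this further position, although the whole exchange, butyl in place of hydrogen five bonds along the chain, still amounts to a 15-fold lower number from compound 1 to compound 3 (1.19 log units; beyond the scatter). Nothing available explains why the second extension behaves differently from the first.

Going by these compounds, whether a still longer chain would keep the number at this level or raise it remains open. So does the outcome of ending the chain in an amine or a carboxylic acid instead of plain saturated carbon.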